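A few compounds are considered here, and "the series" means these few. Any claim that something is new, unique, unknown or untested is made for them only; others in the source may bear on it.

Compound 1 `COc1ccc(C2=NN(C3=NC(=O)/C(=C4\C(=O)Nc5ccc(Br)cc54)S3)C(c3ccc(OC)cc3)C2)cc1`: 270 nM
Compound 2 `COc1ccc(C2=NN(C3=NC(=O)/C(=C4\C(=O)Nc5ccc(Cl)cc54)S3)C(c3ccc(OC)cc3)C2)cc1`: 250 nM
Compound 3 `CN(C)c1ccc(C2CC(c3ccccc3)=NN2C2=NC(=O)/C(=C3\C(=O)Nc4ccc(Br)cc43)S2)cc1`: 270 nM

In a functional assay on cells (Cancer cell lines, Homo sapiens) for cytotoxicity, read by sulforhodamine B assay, with a stated time of 48 h (on this read-out higher numbers stand for weaker inhibition of growth and lower numbers for stronger inhibition of growth), compound 1 gives 270 nM and compound 2 gives 250 nM. The step between them, (chloro in place of bromo on an aromatic carbon), made a 1.1-fold lower number from compound 1 to compound 2 (0.03 log units; within the scatter). Compound 3 carries a different core; the difference between the two cores is not broken down here. In this assay compound 3 gives 270 nM, level with compound 1 at the digits shown.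

Compound 4 `CN(C)c1ccc(C2CC(c3ccccc3)=NN2C2=NC(=O)/C(=C3\C(=O)Nc4ccc(Cl)cc43)S2)cc1` has not yet been measured in this assay. It differs from compound 3 by the same change, (chloro in place of bromo on an aromatic carbon), made at the same place. Because compound 1 to compound 2 gave a 1.1-fold lower number from compound 1 to compound 2 (0.03 log units; within the scatter), the account expects the step from compound 3 to compound 4 to be a 1.1-fold lower number from compound 3 to compound 4 (0.03 log units; within the scatter). Compound 4 is therefore estimated at 250 nM, with a range from 130 nM to 500 nM.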

Compound 4, concentration for 50% growth inhibition: 250 nM
Compound 4: middle estimate and measured number agree at the digits printed; low and high end bracket the measured number.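

In this assay, chloro in place of bromo on an aromatic carbon made a 1.1-fold lower number from compound 3 to compound 4 (0.03 log units; within the scatter) and so matched the step seen on the other core: the same change on two cores in this assay, a 1.1-fold lower number (0.03 log units; within the scatter) from compound 1 to compound 2 and a 1.1-fold lower number (0.03 log units; within the scatter) from compound 3 to compound 4, 1.0-fold (0.00 log units) apart, within the scatter of two such steps. Across these two cores, then, the exchange carries over as a step too small to tell from the scatter, and neither halogen stands apart from the other on either core. Two pairs do not show that the same would hold on any further core, and they say nothing about why the two steps agree.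

The compounds shown leave open how a fluoro, nitro or carboxylic acid group on that aromatic carbon would read. They also leave open what the same carbon would give carrying only hydrogen.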